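A few compounds are considered here, and "the series" means these few. Any claim that something is new, unique, unknown or untested is made for them only; others in the source may bear on it.

Compound 1 `CCS(=O)(=O)Nc1cc(-c2ccc3ncnc(Nc4ccc(F)cc4)c3c2)cnc1OC` gives 3160 nM in a functional assay on HCT-116 cells (Homo sapiens) for cytotoxicity, read by sulforhodamine B assay, with a stated time of 72 h; on this read-out higher numbers stand for weaker inhibition and lower numbers for stronger inhibition; compound 2 `CCS(=O)(=O)Nc1cc(-c2ccc3ncnc(Nc4ccc(OC)c(OC)c4)c3c2)cnc1OC` gives 4360 nM; compound 3 `COC(=O)c1cccc(Nc2ncnc3ccc(-c4cnc(OC)c(NS(=O)(=O)c5ccc(F)cc5F)c4)cc23)c1` gives 1500 nM.

Compound 2 stands at the highest of the three numbers; its gap to compound 1 lies within the scatter, while its gap to compound 3 lies beyond it. Compound 4 `CCS(=O)(=O)Nc1cc(-c2ccc3ncnc(Nc4ccc(F)nc4)c3c2)cnc1OC` differs from compound 2 by 6-fluoropyridin-3-yl in place of 3,4-dimethoxyphenyl on a nitrogen on an aromatic ring. Within the data shown here, the only measured step that bears on this place is a 1.4-fold higher number from compound 1 to compound 2 (0.14 log units; within the scatter), an exchange of the ring on the same nitrogen, which stayed within the scatter. A further exchange at this nitrogen is therefore expected to move this assay by no more than the scatter, with the number for compound 4 expected to fall nearer compound 1 than compound 2. Compound 4 is thus estimated at 3500 nM, within 1200 nM to 10000 nM, an expected step of a 1.2-fold lower number from compound 2 to compound 4 (0.10 log units; within the scatter).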

Compound 4, half-maximal inhibitory concentration: 7620 nM
For compound 4 the middle estimate is 2.2-fold (0.34 log units) below the measured one; low and high end bracket the measured number.
By their numbers in this assay, from the lowest: compound 3; then compounds 1, 2 and 4 (each within the scatter of the next, the first and the last beyond it).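

In this assay, exchanging the ring on this nitrogen now produces a step beyond the scatter: 6-fluoropyridin-3-yl in place of 4-fluorophenyl gives (a 2.4-fold higher number from compound 1 to compound 4 (0.38 log units; beyond the scatter)). The same group in place of 3,4-dimethoxyphenyl stays within the scatter (a 1.7-fold higher number from compound 2 to compound 4 (0.24 log units; within the scatter)), so only the exchange from 4-fluorophenyl separates measurably, and modestly. Still open, as far as these compounds go, is how a carboxylic acid or an amine on this ring would read in this assay. No measurement offered here accounts for these steps.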